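The source may report more compounds than this note shows. Statements on the series, on what has been measured and on what is new or still open speak of the compounds shown alone.

In a functional assay on HCC 2998 cells (Homo sapiens) for inhibition, read by sulforhodamine B assay, with a stated time of 48 h (a higher number here means a weaker inhibitor of growth, a lower number a stronger inhibitor of growth), compound 1 `O=C(Cc1csc2nc(-c3ccc(Br)cc3)cn12)N/N=C/c1ccccc1` gives 13200 nM and compound 2 `COc1cccc(OC)c1/C=N/NC(=O)Cc1csc2nc(-c3ccc(Br)cc3)cn12` gives 10000 nM, so compound 2 stands level with compound 1 within the scatter. Compound 3 `O=C(Cc1csc2nc(-c3ccc(Br)cc3)cn12)N/N=C/c1ccc(Cl)cc1Cl` has 2,4-dichlorophenyl in place of 2,6-dimethoxyphenyl on a carbon with a double bond to nitrogen. Among the measured compounds shown here, only one measured step bears on this place, a 1.3-fold lower number from compound 1 to compound 2 (0.12 log units; within the scatter), and it stays within the scatter, so no change beyond the scatter is expected in this assay. The expected step is a 1.1-fold lower number from compound 2 to compound 3 (0.05 log units; within the scatter). Compound 3 is estimated at 9000 nM, with an expected range of 3500 nM to 22000 nM.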

Compound 3, concentration for 50% growth inhibition: 20000 nM
For compound 3 the middle estimate is 2.2-fold (0.35 log units) below the measured one, and the stated range covers the measured number.
By their numbers in this assay, from the lowest: compounds 2, 1 and 3 (each within the scatter of the next).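

In this assay the change to 2,4-dichlorophenyl gives a 2.0-fold higher number from compound 2 to compound 3 (0.30 log units; within the scatter) and a 1.5-fold higher number from compound 1 to compound 3 (0.18 log units; within the scatter). This position on the carbon with a double bond to nitrogen now carries phenyl, 2,6-dimethoxyphenyl and 2,4-dichlorophenyl, and none of the three stands apart from the others beyond the scatter, whether the added atoms are oxygen or chlorine. No evidence here explains this lack of separation. Still open, going by these compounds, is whether a group of another kind at this place, such as an amine or a carboxylic acid, would move the number beyond the scatter.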